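Series notes: from compound 3 to compound 4

The compounds below may be only part of what the source reports. "The series", "measured", "known", "first", "only" and "open" are said of these compounds alone.

Measured in a physicochemical assay for solubility; a lower number here means a less soluble compound, a higher number a more soluble compound:
- compound 1 `O=C(c1cccc(Cl)c1)N1CCC(NS(=O)(=O)c2cc(S(=O)(=O)c3ccccc3)ccc2C(F)(F)F)CC1` gives 6300 nM
- compound 2 `O=C(c1ccc(Cl)cc1)N1CCC(NS(=O)(=O)c2cc(S(=O)(=O)c3ccccc3)ccc2C(F)(F)F)CC1` gives 3100 nM
- compound 3 `O=C(C1CCNCC1)N1CCC(NS(=O)(=O)c2cc(S(=O)(=O)c3ccccc3)ccc2C(F)(F)F)CC1` gives 100000 nM

Compound 3 stands highest of the three measured compounds. Compound 4 `O=C(CC1CCNCC1)N1CCC(NS(=O)(=O)c2cc(S(=O)(=O)c3ccccc3)ccc2C(F)(F)F)CC1` differs from it by (piperidin-4-yl)methyl in place of piperidin-4-yl on a carbonyl carbon, with (piperidin-4-yl)methyl in place of piperidin-4-yl on a carbonyl carbon. The large steps of a 16-fold higher number from compound 1 to compound 3 (1.20 log units; beyond the scatter) and a 32-fold higher number from compound 2 to compound 3 (1.51 log units; beyond the scatter) bear on this position, but both replace a chlorophenyl group. The modest step of a 2.0-fold lower number from compound 1 to compound 2 (0.31 log units; beyond the scatter) only exchanges one chlorophenyl group for the other. For the measured compounds named here, no measured step tests this smaller change, so no step beyond the scatter is expected in this assay. Compound 4 is estimated at 80000 nM, with an expected range of 35000 nM to 160000 nM. This estimate means an expected 1.3-fold lower number from compound 3 to compound 4 (0.10 log units; within the scatter).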

Compound 4, solubility: 100000 nM
For compound 4 the middle estimate is 1.3-fold (0.10 log units) below the measured one, within the range that was stated.
By their numbers in this assay, from the lowest: compound 2; then compound 1; then compounds 3 and 4 (each within the scatter of the next).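

In this assay putting (piperidin-4-yl)methyl in place of piperidin-4-yl on the carbonyl carbon gives no change at the digits printed from compound 3 to compound 4 (within the scatter) at this position. The large gap to the chlorophenyl compounds also holds for (piperidin-4-yl)methyl, with a 32-fold higher number from compound 2 to compound 4 (1.51 log units; beyond the scatter) and a 16-fold higher number from compound 1 to compound 4 (1.20 log units; beyond the scatter) on the same carbonyl carbon. Still open, as far as these compounds go, is how a longer chain carrying the same ring, an open-chain amine or a carboxylic acid on this carbonyl carbon would read in this assay for this series. No measurement at hand accounts for this result.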